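The compounds below may be only part of what the source reports. "The series", "measured", "known", "first", "only" and "open" are said of these compounds alone.

Compound 1 `COC(=O)c1cc(-c2cccc(NC(=O)c3ccc(/C=C/C(=O)c4cccs4)cc3)c2)on1`: "not determined" (no result reported)
Compound 2 `COC(=O)c1cc(-c2cccc(NC(=O)c3ccc(/C=C/C(=O)c4ccc(F)cc4)cc3)c2)on1`: > 20 ug/mL

In an ADME assay on Vero cells (Chlorocebus sabaeus) for cytotoxicity, read by MTT assay, with a stated time of 72 h (on this read-out lower numbers stand for higher toxicity in this test and higher numbers for lower toxicity in this test), compound 2 gives only a limit, > 20 ug/mL, and not a number. Compound 1 has no result in this assay: "not determined" (no result reported). For the measured compounds named here, the single piece of evidence is therefore (the limit of > 20 ug/mL in this assay, at which 1 of the 2 values shown sits). Compound 3 `COC(=O)c1cc(-c2cccc(NC(=O)c3ccc(/C=C/C(=O)c4cccc(C(F)(F)F)c4)cc3)c2)on1` differs from compound 2 by 3-(trifluoromethyl)phenyl in place of 4-fluorophenyl on a carbonyl carbon. Going by the values given here, no step between measured compounds is known here, so for compound 3 no shift beyond the scatter is expected, and the estimated step is a step that the limit leaves unreadable from compound 2 to compound 3. Compound 3 is expected to give about 25 ug/mL, in the range 10 ug/mL to 60 ug/mL, most likely again as a limit.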

Compound 3, half-maximal cytotoxic concentration: > 20 ug/mL
Compound 3 ended at the assay's limit (the forecaster's own chance of this, stated with the estimate: 70%); the middle value is on the limit's open side.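

In this assay, for the compounds shown here, compound 2 and compound 3 each give only a limit, so no step between them can be read. As far as these compounds go, whether 3-(trifluoromethyl)phenyl in place of 4-fluorophenyl on a carbonyl carbon changes the half-maximal cytotoxic concentration at all remains open.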